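Dichloro to difluoro on the carbonyl-bearing ring

This account rests on a few compounds, and the source may have more. Where it says the series, first, only, none or still open, it means among the compounds named here.

Measured compounds:
Compound 1 `COc1ccc(-c2cc(/C=C/C(=O)c3ccc(N)cc3)[nH]n2)cc1` gives 1900 nM in a functional assay on UACC-257 cells (Homo sapiens) for inhibition, read by sulforhodamine B assay, with a stated time of 48 h; on this read-out higher numbers stand for weaker inhibition of growth and lower numbers for stronger inhibition of growth.
Compound 2 `COc1cc(-c2cc(/C=C/C(=O)c3ccc(Cl)c(Cl)c3)[nH]n2)cc(OC)c1OC` gives 16300 nM in this assay.
Compound 3 `COc1ccc(C(=O)/C=C/c2cc(-c3cc(OC)c(OC)c(OC)c3)n[nH]2)cc1OC` gives 1490 nM in this assay.

Compound 2 carries the highest number of the three, so it shows the weakest inhibition of growth among them. For the measured compounds named here, compound 1 sits nearest to it, and compound 3 lies furthest away; the one measured step from compound 2 is an 11-fold lower number from compound 2 to compound 3 (1.04 log units; beyond the scatter), where 3,4-dimethoxyphenyl replaces 3,4-dichlorophenyl on the carbonyl carbon.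

The unmeasured compound 4 `COc1cc(-c2cc(/C=C/C(=O)c3ccc(F)c(F)c3)[nH]n2)cc(OC)c1OC` differs from compound 2 by 3,4-difluorophenyl in place of 3,4-dichlorophenyl on a carbonyl carbon. Going by the values given here, no measured step covers this exact exchange of two halogens. Among the compounds with values here, the only step that starts from compound 2 swaps the dichlorophenyl for a dimethoxyphenyl and brings a large drop in the number; an exchange of chlorine for fluorine at the same two positions keeps far more of the original group, so a smaller move is more plausible. The author therefore expects compound 4 to land somewhat lower than compound 2, as a step of a 2.0-fold lower number from compound 2 to compound 4 (0.31 log units; beyond the scatter), with the possibility that it stays within the scatter. The estimated value for compound 4 is 8000 nM, with a range from 3000 nM to 25000 nM.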

Compound 4, concentration for 50% growth inhibition: 1750 nM
Estimate against measurement, compound 4: 4.6-fold (0.66 log units) above, outside the stated range (below it).
By their numbers in this assay, from the lowest: compounds 3, 4 and 1 (each within the scatter of the next); then compound 2.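

In this assay the exchange of one halogen pair for another at this place, on a carbonyl carbon whose other neighbour is a double-bonded chain carbon, is far from silent: the result is a 9.3-fold lower number from compound 2 to compound 4 (0.97 log units; beyond the scatter). The earlier compounds showed a large step only for the exchange of 3,4-dichlorophenyl for 3,4-dimethoxyphenyl, an 11-fold lower number from compound 2 to compound 3 (1.04 log units; beyond the scatter), and the new step shows that a change of that size does not need the halogens to leave the ring; with a 1.2-fold higher number from compound 3 to compound 4 (0.07 log units; within the scatter), the 3,4-difluorophenyl and 3,4-dimethoxyphenyl compounds cannot be told apart, and among these three compounds only compound 2, with its 3,4-dichlorophenyl group, stands apart. Nothing available here explains why the two halogen pairs give such different numbers.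

The compounds shown leave open whether a 3,4-dibromophenyl or an unsubstituted phenyl group at this place would read like compound 2 or like compound 4, and whether one chlorine atom alone accounts for the gap. They also leave open where a ring bearing a nitrile or a trifluoromethyl group would fall on this scale.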